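Amide substituent exchange on the shared core series

The source may report more compounds than this note shows. Statements on the series, on what has been measured and on what is new or still open speak of the compounds shown alone.

In an ADME assay on HaCaT cells (Homo sapiens) for inhibition (a lower number here means a stronger inhibitor, a higher number a weaker inhibitor), compound 1 `COc1cc(-c2cc(C(=O)O)c3ccccc3n2)ccc1OCC(=O)Nc1cccc(C)c1` gives 225000 nM and compound 2 `COc1cc(-c2cc(C(=O)O)c3ccccc3n2)ccc1OCC(=O)Nc1cccc(Cl)c1` gives 192000 nM under the same conditions. Compound 3 `COc1cc(-c2cc(C(=O)O)c3ccccc3n2)ccc1OCC(=O)Nc1ccccc1C(F)(F)F` gives 102000 nM in this assay, the lowest of the three numbers; the step of a 2.2-fold lower number from compound 1 to compound 3 (0.34 log units; beyond the scatter) is beyond the scatter, whereas a 1.9-fold lower number from compound 2 to compound 3 (0.27 log units; within the scatter) and a 1.2-fold lower number from compound 1 to compound 2 (0.07 log units; within the scatter) are not. Compound 4 `COc1cc(-c2cc(C(=O)O)c3ccccc3n2)ccc1OCC(=O)NCc1ccco1` differs from compound 3 by (furan-2-yl)methyl in place of 2-(trifluoromethyl)phenyl on an amide-type nitrogen and nothing else. Among the compounds with values here, no measured pair carries this exact exchange; the steps that vary the same nitrogen, a 2.2-fold lower number from compound 1 to compound 3 (0.34 log units; beyond the scatter) and a 1.9-fold lower number from compound 2 to compound 3 (0.27 log units; within the scatter), were modest or within the scatter, so the move to compound 4 is expected to stay near the scatter, with a higher number somewhat more likely than a lower one. Compound 4 is therefore estimated at 150000 nM in this assay, between 70000 nM and 350000 nM as the range, an expected step of a 1.5-fold higher number from compound 3 to compound 4 (0.17 log units; within the scatter) in size.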

Compound 4, half-maximal inhibitory concentration: > 300000 nM
Compound 4 was reported as a limit; the forecaster's own chance of this, stated with the estimate: 15%; middle value at least 2.0-fold (0.30 log units) from the limit.
By their numbers in this assay, from the lowest: compounds 3, 2 and 1 (each within the scatter of the next, the first and the last beyond it). At a limit, above all of these: compound 4.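

In this assay compound 4 is a limit, not a number: the limit of > 300000 nM in this assay, at which 1 of the 4 values shown sits. (Furan-2-yl)methyl in place of 2-(trifluoromethyl)phenyl on the amide-type nitrogen gives an at least 2.9-fold higher number from compound 3 to compound 4 (0.46 log units; beyond the scatter), so this nitrogen's substituent can raise the number beyond the scatter, not only lower it. The floors of an at least 1.5-fold higher number from compound 2 to compound 4 (0.19 log units; that floor lies within the scatter) and an at least 1.3-fold higher number from compound 1 to compound 4 (0.12 log units; that floor lies within the scatter) lie within the scatter and do not separate compound 4 from those two.

As far as these compounds go, it remains open whether the furan ring or its methyl link drives the step. A benzyl or 2-(trifluoromethyl)benzyl group on the same nitrogen would separate the two.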